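The compounds below may be only part of what the source reports. "The series", "measured", "known", "first", "only" and "open" are said of these compounds alone.

In a functional assay for inhibition, with Homo sapiens as the target (a lower number here means a stronger inhibitor, a higher number a weaker inhibitor), compound 1 (`O=C(O)CCCCCCCCn1nc(-c2ccccc2)c(-c2ccccc2)c1-c1ccccc1`), which carries a 2-carboxyethyl group on its chain, gives 400 nM. Compound 2 (`CC(C)(C)OC(=O)COCCCCCCn1nc(-c2ccccc2)c(-c2ccccc2)c1-c1ccccc1`) is recorded at > 62000 nM, and this figure is a limit of the assay, not a number. Among the measured compounds shown here, it is the only measured step, an at least 150-fold higher number from compound 1 to compound 2 (2.19 log units; beyond the scatter), that bears on what follows. That large step put (tert-butoxycarbonyl)methoxy in place of 2-carboxyethyl.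

Compound 3 (`O=C(O)COCCCCCCn1nc(-c2ccccc2)c(-c2ccccc2)c1-c1ccccc1`) arises from compound 2 through one change, hydrogen in place of tert-butyl on an oxygen next to a carbonyl group, so that tert-butoxycarbonyl becomes carboxy. The chain of compound 2 otherwise stays as it is, and compound 3 ends in a carboxy group, as compound 1 does. Most of the measured step is therefore expected to be undone, which would mean a large move to a lower number in this assay, towards the 400 nM of compound 1. The expected change is an at least 100-fold lower number from compound 2 to compound 3 (2.01 log units; beyond the scatter). For compound 3 the estimate is 600 nM, with an expected range from 150 nM to 3000 nM.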

Compound 3, half-maximal inhibitory concentration: 440 nM
Beside the measured number, compound 3's estimate is 1.4-fold (0.13 log units) above it; measured number inside the range.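

In this assay, hydrogen in place of tert-butyl on an oxygen next to a carbonyl group gives an at least 140-fold lower number from compound 2 to compound 3 (2.14 log units; beyond the scatter). This single change turns tert-butoxycarbonyl into carboxy with the rest of the chain untouched, whereas the earlier step had altered the end group and the chain together. Carboxymethoxy in place of 2-carboxyethyl on a saturated chain carbon, six bonds along the chain from an aromatic nitrogen, gives a 1.1-fold higher number from compound 1 to compound 3 (0.04 log units; within the scatter), which lies within the scatter, so the two carboxy-ended chains cannot be told apart in this read-out, while the true size of the step from compound 2 stays unknown because compound 2 is recorded only as a limit of the assay, not a number: the limit of > 62000 nM in this assay, at which 1 of the 3 values shown sits.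

The compounds shown leave open whether the end of the chain must be a carboxylic acid, or whether an amide, a tetrazole or a methyl ester would serve there as well. They also leave open how a shorter or a longer chain ending in carboxy would read, and what a fluorine or a methoxy group on the shared core would do.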